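The source may report more compounds than this note shows. Statements on the series, on what has been measured and on what is new or still open speak of the compounds shown alone.

Compound 1 `CC(=O)OC[C@H]1O[C@H](OC[C@@H](Cn2cc(CN(c3nc(-c4ccc(Cl)cc4)no3)C3CCCCC3)nn2)OC(C)=O)C=C[C@@H]1OC(C)=O` was tested in an ADME assay on HepG2 cells (Homo sapiens) for cytotoxicity, read by MTT assay, with a stated time of 48 h (a lower number here means that less compound is tolerated, a higher number that more compound is tolerated), and gave 46.9 ug/mL. Among the three compounds measured so far, compound 1 stands second highest. Its nearest neighbour is compound 3 `C#CCN(c1nc(-c2ccc(Cl)cc2)no1)C1CCCCC1`, which in this assay gives 41.3 ug/mL, a value within the scatter of that of compound 1. Compound 2 `C#CCN(c1nc(-c2ccc(C)cc2)no1)C1CCCCC1` gives 91.9 ug/mL in this assay, and this value also lies within the scatter of the value of compound 1.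

Compound 4 `COc1ccc(-c2noc(N(Cc3cn(C[C@H](CO[C@@H]4C=C[C@H](OC(C)=O)[C@@H](COC(C)=O)O4)OC(C)=O)nn3)C3CCCCC3)n2)cc1` differs from compound 1 in one place: methoxy in place of chloro on an aromatic carbon. Among the measured compounds shown here, the only measured step that touches this same aromatic carbon is a 2.2-fold lower number from compound 2 to compound 3 (0.35 log units; beyond the scatter), a change from methyl to chloro that lowered the number beyond the scatter, though only modestly. For the measured compounds named here, no measured compound carries a methoxy group at this carbon, so the direction of the new change cannot be read directly from the data. Since the two groups tested there so far differ only modestly, a step of similar or smaller size is expected for compound 4, most likely upward from the chloro compound or within the scatter. Compound 4 is therefore expected to give about 60 ug/mL in this assay, with a likely range from 30 ug/mL to 120 ug/mL. The expected step, a 1.3-fold higher number from compound 1 to compound 4 (0.11 log units; within the scatter), is estimated to be small and may well stay within the scatter.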

Compound 4, half-maximal cytotoxic concentration: 141 ug/mL
For compound 4 the middle estimate is 2.4-fold (0.37 log units) below the measured one; measured number above the stated range.
By their numbers in this assay, from the lowest: compounds 3, 1, 2 and 4 (each within the scatter of the next, the first and the last beyond it).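

The step of a 3.0-fold higher number from compound 1 to compound 4 (0.48 log units; beyond the scatter) shows that this aromatic carbon, para to a large group, still affects the tolerated concentration in this assay when the core of compound 1 is present, and that the size of this effect goes beyond the scatter. It also adds a second pair to the earlier one, a 2.2-fold lower number from compound 2 to compound 3 (0.35 log units; beyond the scatter), and in both pairs the compound with the chloro group has the lower number, so among these four compounds chloro is the less tolerated choice at this carbon, with no pair going against this. Nothing shown here explains why swapping chloro for methoxy has this effect.

From the compounds shown here alone, the two pairs rest on different cores and compare chloro with different groups, so it remains open how methyl would behave on the core of compound 1 and methoxy on the core of compound 2. Going by these compounds, it also remains open whether the number keeps rising with other groups at this carbon, such as an amine, a carboxylic acid or a longer ether chain, or whether the 4-methoxyphenyl result is specific to methoxy.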